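The source may hold more compounds than are shown below. What is called first, only, known or untested is meant among the compounds shown, and "the series" means these compounds.

In an ADME assay on cells (Astrocyte, Rattus norvegicus, strain Wistar) for inhibition, read by sulforhodamine B assay, with a stated time of 72 h (a higher number here means that more compound is tolerated, a lower number that less compound is tolerated), compound 3 (`CC(C)(C)c1ccc(C(=O)/C=C/c2ccco2)cc1`) gives 88700 nM. Compound 2 (`O=C(/C=C/c1ccc([N+](=O)[O-])o1)c1ccc(C2CCCCC2)cc1`) gives 57200 nM, and the gap between compound 2 and compound 3 lies within the usual scatter. Compound 1 (`CCCCc1ccc(C(=O)/C=C/c2ccc([N+](=O)[O-])o2)cc1`) gives 41200 nM. The gap between compound 1 and compound 3 lies beyond the scatter.

Compound 4 (`CCCCc1ccc(C(=O)/C=C/c2ccco2)cc1`) is built from the same atoms as compound 3, joined differently, with butyl in place of tert-butyl on an aromatic carbon. Within the data shown here, no measured pair shows this exact exchange, so the evidence is indirect. The closest comparison is a 1.4-fold higher number from compound 1 to compound 2 (0.14 log units; within the scatter), where a butyl group gives way to a cyclohexyl group at the same kind of aromatic carbon. That step stays within the scatter, which suggests that changing this group need not move the number far, although tert-butyl itself does not take part in it. Compound 1, which also carries butyl, has the lowest value of the three, so a slightly lower number is the more likely direction, but no step beyond the scatter is expected.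

The expected change is a 1.3-fold lower number from compound 3 to compound 4 (0.10 log units; within the scatter). For compound 4, the estimated value is 70000 nM, with an expected range from 38000 nM to 125000 nM.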

Compound 4, half-maximal cytotoxic concentration: > 100000 nM
Compound 4: no number, only a limit (the forecaster's own chance of this, stated with the estimate: 5%); middle value at least 1.4-fold (0.15 log units) from the limit.
By their numbers in this assay, from the lowest: compounds 1, 2 and 3 (each within the scatter of the next, the first and the last beyond it). At a limit, above all of these: compound 4.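

In this assay compound 4 reads > 100000 nM, which is a limit of the assay and not a number, so any step to it gives only a floor: the limit of > 100000 nM in this assay, at which 1 of the 4 values shown sits. Among these compounds, the clearest new information concerns the nitro group: with butyl held constant, hydrogen in place of nitro on an aromatic carbon gives an at least 2.4-fold higher number from compound 1 to compound 4 (0.38 log units; beyond the scatter), the first one-place change here to pass the scatter, since compounds 1 and 3 differ in two places and could not separate the nitro group from the alkyl group. Butyl in place of tert-butyl gives an at least 1.1-fold higher number from compound 3 to compound 4 (0.05 log units; that floor lies within the scatter), a floor that stays within the scatter, so this pair shows no measurable cost of the straight chain and cannot size the change at this para position, whose true gap may be larger.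

The compounds shown do not reveal how far compound 4 really lies past the limit, or whether cyclohexyl would behave like butyl once the nitro group is gone. They also leave open how a nitrile or an amine on that same aromatic carbon, or a chain longer than butyl on the six-membered ring, would compare.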